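Benzothiazole amide series, U2OS antiproliferative readout

The source may hold more compounds than are shown below. What is called first, only, known or untested is meant among the compounds shown, and "the series" means these compounds.

Compound 1 `O=C(CSc1ncccn1)Nc1ccc2nc(NC(=O)c3ccc(C(F)(F)F)cc3)sc2c1` is the reference point of the set. In a functional assay on U2OS cells (Homo sapiens) for antiproliferative activity, read by MTT assay, with a stated time of 72 h (a lower number here means a stronger inhibitor, a higher number a weaker inhibitor), compound 1 gives 28100 nM, the lowest of the two numbers recorded. Compound 3 `CCn1c(CNc2ccc(OC)cc2)nnc1SCC(=O)Nc1ccc(Cl)cc1` sits nearest, and in this assay compound 3 gives 63500 nM, a gap beyond the usual scatter. Compound 2 `CC(O)c1cccc(NC(=O)c2cc(Br)ccc2Br)c1` returns only a limit: in this assay compound 2 gives > 100000 nM, which marks the edge of the assay rather than a number (the limit of > 100000 nM in this assay, at which 1 of the 3 values shown sits). Among the compounds with values here, compounds 2 and 3 share no single-point relation with compound 1, so no step between measured compounds is available.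

Compound 4 `Cc1ccc(SCC(=O)Nc2ccc3nc(NC(=O)c4ccc(C(F)(F)F)cc4)sc3c2)c(C)c1` is the next analogue, differing from compound 1 in one place: 2,4-dimethylphenyl in place of pyrimidin-2-yl on a sulfur. Without a measured step of this kind in the series, no direction can be read from the data. The expectation is that the change from compound 1 to compound 4 stays close to the scatter, a 1.4-fold lower number from compound 1 to compound 4 (0.15 log units; within the scatter). Compound 4 is therefore expected to give 20000 nM in this assay, with a plausible range from 6000 nM to 70000 nM.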

Compound 4, half-maximal inhibitory concentration: 1000 nM
Compound 4: middle estimate off by 20-fold (1.30 log units), on the high side, and the stated range ends above it.
By their numbers in this assay, from the lowest: compound 4; then compound 1; then compound 3. At a limit, above all of these: compound 2.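

In this assay, the group on a sulfur whose other neighbours are a saturated chain carbon now has a measured step, and it is a large one: 2,4-dimethylphenyl in place of pyrimidin-2-yl gives a 28-fold lower number from compound 1 to compound 4 (1.45 log units; beyond the scatter) with the rest of compound 1 unchanged. Within the data shown here, the reading therefore responds strongly to this one position, which the earlier compounds could not show. The change replaces a ring with hetero atoms by a carbon-only ring and also adds the methyl groups, so this single step does not separate those two parts, and no measurement shown bears on why the step is this large.

Going by these compounds, it remains open whether plain phenyl would keep the lower number or whether the methyl groups are needed. On these data alone, the effect of an amine or a carboxylic acid on this ring also remains open.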